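Swapping the sulfonyl aryl group: from formylphenyl to bromothiophene

The source may hold more compounds than are shown below. What is called first, only, known or untested is meant among the compounds shown, and "the series" means these compounds.

Compound 1, `COC(=O)c1cc(=O)c2cc(N)ccc2[nH]1`: in a functional assay on HepG2 cells (Homo sapiens) for antiproliferative activity, with a stated time of 72 h (on this read-out higher numbers stand for an effect only at larger amounts of compound and lower numbers for an effect already at smaller amounts), compound 1 reached only the limit of > 33700 nM.
Compound 2, `COc1ccc(-c2cc(=O)c3c(OC)cc(OC)cc3n2S(=O)(=O)c2ccc(C=O)cc2)cc1`: in this assay compound 2 likewise reached only the limit of > 34400 nM.

Both measured values are limits of the method rather than numbers; the limit of > 33700 nM in this assay, at which 1 of the 2 values shown sits, and the limit of > 34400 nM in this assay, at which 1 of the 2 values shown sits, show where they sit. Compound 2 therefore stands at the edge of what the assay can report, and nothing places it above or below compound 1.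

Compound 3, `COc1ccc(-c2cc(=O)c3c(OC)cc(OC)cc3n2S(=O)(=O)c2ccc(Br)s2)cc1`, differs from compound 2 in one place (5-bromothiophen-2-yl in place of 4-formylphenyl on a sulfonyl sulfur). The rest of the molecule, including the shared core with its two methoxy groups and the methoxyphenyl substituent, is unchanged. For the measured compounds named here, with no measured step to lean on, the expected step from compound 2 to compound 3 is a step that the limit leaves unreadable from compound 2 to compound 3, that is, no change beyond the scatter. Compound 3 is accordingly estimated at 35000 nM, with a range from 8000 nM to 120000 nM, and most likely the assay will again report only a limit.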

Compound 3, half-maximal effective concentration: > 48200 nM
Compound 3 was reported as a limit; the forecaster's own chance of this, stated with the estimate: 80%; middle value at least 1.3-fold (0.13 log units) away from the limit.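

For the compounds shown here, compound 2 and compound 3 each gave only a limit, not a number, in this assay, and no step between them can be read. The compounds shown leave open whether either acts on these cells at larger amounts, and whether 5-bromothiophen-2-yl in place of 4-formylphenyl changes that.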